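Nitro in place of hydrogen on compound 1

The compounds below may be only part of what the source reports. "The series", "measured", "known", "first", "only" and "open" are said of these compounds alone.

In a functional assay on HO8910 cells (Homo sapiens) for inhibition, read by MTT assay, with a stated time of 24 h, tested at 10 ug/mL (a lower number here means less inhibition of growth, a higher number more inhibition of growth at the concentration tested), compound 1 (`O=C(CCCCC1CCSS1)Nc1cccc(C(F)(F)F)c1`) gives 5.99%. Compound 2 (`O=C(CCCCC1CCSS1)Nc1ccc(OC(F)(F)F)cc1`) gives 8.57%. These two numbers lie within the usual scatter of each other, so compound 1 stands level with compound 2, and neither shows much inhibition at the concentration tested. Among the compounds with values here, no measured pair differs in only one place, so the data show no direct effect of a single change. Compound 3 (`O=C(CCCCC1CCSS1)Nc1ccc([N+](=O)[O-])c(C(F)(F)F)c1`) has nitro in place of hydrogen on an aromatic carbon of compound 1, ortho to a trifluoromethyl group and para to a large group: nitro in place of hydrogen on an aromatic carbon. A small rise in inhibition is expected, no larger than the scatter. The estimated change is a number 5 percentage points higher from compound 1 to compound 3 (within the scatter). In this assay, compound 3 is estimated at 11%, with an expected range of 3% to 25%.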

Compound 3, percent growth inhibition at one concentration: "not active" (no number reported)
Nothing numeric was reported for compound 3; the estimate stays without a comparison.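

In this assay, within the data shown here, compound 3 is reported only as not active, without a number, so no step from compound 1 to compound 3 can be read. The compounds shown leave open how far nitro in place of hydrogen shifts growth inhibition. Nothing available here bears on this result.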